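Swapping the thiophene for an aminophenyl on the shared core

The compounds below may be only part of what the source reports. "The series", "measured", "known", "first", "only" and "open" are said of these compounds alone.

Of the compounds shown here, three built on one shared core have been measured in a functional assay on NCI-H460 cells (Homo sapiens) for inhibition, read by sulforhodamine B assay, with a stated time of 48 h; on this read-out higher numbers stand for weaker inhibition of growth and lower numbers for stronger inhibition of growth. Compound 1 `COC(=O)c1sc2cc(-c3ccsc3)cnc2c1N` gives 12400 nM, the highest of the two plain numbers obtained; compound 3 `COC(=O)c1sc2cc(-c3cncc4ccccc34)cnc2c1N` gives 7700 nM, which lies within the usual scatter of that result, so the two cannot be ranked. Compound 2 `COC(=O)c1sc2cc(-c3ccoc3)cnc2c1N` gives only a limit of the assay, > 120000 nM. Going by the values given here, the one step that connects two measured compounds, an at least 9.6-fold higher number from compound 1 to compound 2 (0.98 log units; beyond the scatter), shows that changing the five-membered ring on that position can weaken growth inhibition sharply, as far as the limit of > 120000 nM in this assay, at which 1 of the 3 values shown sits, allows one to tell.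

Compound 4 `COC(=O)c1sc2cc(-c3ccc(N)cc3)cnc2c1N` is not yet measured. It differs from compound 1 by 4-aminophenyl in place of thiophen-3-yl on an aromatic carbon. Among the compounds with values here, no measured step involves a six-membered carbon ring at this position, so the move from compound 1 to compound 2 only warns that the group matters, without pointing a direction. The expectation for compound 4 is therefore a step of about a 1.2-fold lower number from compound 1 to compound 4 (0.09 log units; within the scatter), with wide uncertainty. Compound 4 is estimated to give 10000 nM, expected to fall between 2500 nM and 45000 nM in this assay.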

Compound 4, concentration for 50% growth inhibition: 37100 nM
Compound 4: middle estimate off by 3.7-fold (0.57 log units), on the low side; measured number inside the range.
By their numbers in this assay, from the lowest: compounds 3 and 1 (each within the scatter of the next); then compound 4. At a limit, above all of these: compound 2.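

A six-membered carbon ring at this position still gives a plain number in this assay, but 4-aminophenyl does not keep up with thiophen-3-yl: the change gives a 3.0-fold higher number from compound 1 to compound 4 (0.48 log units; beyond the scatter). The same position also separates 4-aminophenyl from furan-3-yl, with an at least 3.2-fold lower number from compound 2 to compound 4 (0.50 log units; beyond the scatter), so the three groups now fall into a clearer order on this read-out. Compound 2 stands only at a limit, so that second step gives a bound and not a size: the limit of > 120000 nM in this assay, at which 1 of the 4 values shown sits.

The compounds shown do not tell whether the weaker growth inhibition of compound 4 belongs to the six-membered ring itself or to its amine, a question that plain phenyl would address. They also leave open how a hydroxyl or a carboxylic acid in place of that amine would read.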